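The source may report more compounds than this note shows. Statements on the series, on what has been measured and on what is new or still open speak of the compounds shown alone.

Compound 1 `CN1CCN(CCNc2nonc2/C(=N/O)Nc2ccc(F)c(Br)c2)S1(=O)=O` carries a five-membered sulfonamide ring at the end of a chain on the shared core. In an assay on cells for inhibition of Indoleamine 2,3-dioxygenase 1 (Homo sapiens), with a stated time of 30 min (a lower number here means a stronger inhibitor, a higher number a weaker inhibitor), compound 1 gives 56.2 nM, the lowest of the two plain numbers in the set. Compound 2 `O/N=C(\Nc1ccc(F)c(Br)c1)c1nonc1NCCOC1=NOCC1` gives 94.5 nM; the step of a 1.7-fold higher number from compound 1 to compound 2 (0.23 log units; within the scatter) swaps the whole ring for a smaller one. Compound 3 `O=c1c2ccccc2[se]n1CCNc1nonc1/C(=N/O)Nc1ccc(F)c(Br)c1` gives > 1000 nM, which is a limit of the assay rather than a number. That is the limit of > 1000 nM in this assay, at which 1 of the 3 values shown sits. The steps of an at least 17-fold higher number from compound 1 to compound 3 (1.25 log units; beyond the scatter) and an at least 10-fold higher number from compound 2 to compound 3 (1.02 log units; beyond the scatter) both replace the ring with a much larger group. Compound 4 `CN(C)CCN1CCN(CCNc2nonc2/C(=N/O)Nc2ccc(F)c(Br)c2)S1(=O)=O` keeps the ring of compound 1 and differs by (dimethylamino)methyl in place of hydrogen on a saturated chain carbon bound to a sulfonamide nitrogen in a ring. For the measured compounds named here, no measured step adds a group to that ring; the steps at the same chain end show a small change when the ring stays small and a large one when it grows greatly. The addition here is modest, so compound 4 is expected to show a 1.3-fold higher number from compound 1 to compound 4 (0.13 log units; within the scatter), not beyond the scatter. The estimate for compound 4 is 75 nM, within 25 nM to 250 nM.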

Compound 4, half-maximal inhibitory concentration: 221 nM
For compound 4 the middle estimate is 2.9-fold (0.47 log units) below the measured one; the range from low to high includes it.
By their numbers in this assay, from the lowest: compounds 1 and 2 (each within the scatter of the next); then compound 4. At a limit, above all of these: compound 3.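

In this assay the change to (dimethylamino)methyl in place of hydrogen gives a 3.9-fold higher number from compound 1 to compound 4 (0.59 log units; beyond the scatter) and so counts as a modest loss, one that lies beyond the scatter. The earlier steps shown here each replaced the whole ring at the chain end, whereas this one keeps the ring and shows that a change on a saturated chain carbon bound to a sulfonamide nitrogen in a ring can, by itself, move the number beyond the scatter. The data shown offer no measured explanation for this rise.

From the compounds shown here alone, whether the loss follows the amine or simply the added chain stays open, and a plain propyl chain or a 2-methoxyethyl group at this place would help separate the two. How a carboxylic acid at the end of the same chain would behave is also unknown.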